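A dimethylphenyl isomer: from compound 3 to compound 4

The source may hold more compounds than are shown below. What is called first, only, known or untested is meant among the compounds shown, and "the series" means these compounds.

Measured in a physicochemical assay for permeability, using PAMPA; a lower number here means that the compound crosses the layer more slowly, a higher number that the compound crosses the layer faster:
- Compound 1 `Cc1ccc(C)c(-c2nc(CN3CCC(C(=O)NCCCN4C[C@H](C)C[C@H](C)C4)CC3)c(C)o2)c1`: "not determined" (no result reported)
- Compound 2 `Cc1oc(-c2ccc(Cl)cc2)nc1CN1CCC(C(=O)NCCCN2C[C@H](C)C[C@H](C)C2)CC1`: > 635 10^-6 cm/s
- Compound 3 `Cc1ccc(-c2nc(CN3CCC(C(=O)NCCCN4C[C@H](C)C[C@H](C)C4)CC3)c(C)o2)cc1C`: 219 10^-6 cm/s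

Within the data shown here, compound 3 holds the only exact number, 219 10^-6 cm/s. Compound 2 gives > 635 10^-6 cm/s, which is a limit of the assay and not a number. Compound 4 `Cc1cc(C)cc(-c2nc(CN3CCC(C(=O)NCCCN4C[C@H](C)C[C@H](C)C4)CC3)c(C)o2)c1` has the same atoms as compound 3, joined differently: 3,5-dimethylphenyl in place of 3,4-dimethylphenyl on an aromatic carbon. One measured step changes the group at this same aromatic carbon: an at least 2.8-fold lower number from compound 2 to compound 3 (0.46 log units; beyond the scatter). That step replaced a different group, however, so it gives only loose guidance for this exchange of isomers. In this assay the expected step is a 1.1-fold higher number from compound 3 to compound 4 (0.02 log units; within the scatter), which means none beyond the scatter. For compound 4 the estimated value is 230 10^-6 cm/s, with an expected range from 110 10^-6 cm/s to 500 10^-6 cm/s.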

Compound 4, apparent permeability: 864 10^-6 cm/s
For compound 4 the middle estimate is 3.8-fold (0.57 log units) below the measured one; measured number outside the range, above it.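

In this assay, the two dimethylphenyl isomers have the same atoms and the same computed counts, yet the change gives a 3.9-fold higher number from compound 3 to compound 4 (0.60 log units; beyond the scatter). Among these compounds, at this aromatic carbon, then, the arrangement of the two methyl groups on the phenyl ring alone separates the numbers, which the earlier compounds, differing in their atoms, could not show. Compound 2 stands at a limit of the assay, so its step to compound 4 cannot be read: the limit of > 635 10^-6 cm/s in this assay, at which 1 of the 4 values shown sits.

As far as these compounds go, whether methoxy or trifluoromethyl groups in place of the methyl groups would track compound 3 or compound 4 remains open. So does the number for an unsubstituted phenyl ring at this carbon.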